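The source may hold more compounds than are shown below. What is called first, only, known or untested is meant among the compounds shown, and "the series" means these compounds.

Of the compounds shown here, three built on a shared core have been tested in a functional assay on HCT-116 cells (Homo sapiens) for antiproliferative activity, read by MTT assay, with a stated time of 72 h; a higher number here means a weaker inhibitor, a lower number a stronger inhibitor. Compound 1 `CN(C(=O)c1ccc(F)cc1)c1ccc2[nH]c(-c3n[nH]c4ccccc34)cc2n1` gives 9270 nM. Compound 2 `CN(C(=O)c1ccco1)c1ccc2[nH]c(-c3n[nH]c4ccccc34)cc2n1` gives 30000 nM. Compound 3 `CN(c1ccc2[nH]c(-c3n[nH]c4ccccc34)cc2n1)S(=O)(=O)c1ccc(Cl)cc1` gives 5980 nM. Between these, the step of a 3.2-fold higher number from compound 1 to compound 2 (0.51 log units; beyond the scatter) and the step of a 5.0-fold lower number from compound 2 to compound 3 (0.70 log units; beyond the scatter) both lie beyond the scatter, while the step of a 1.6-fold lower number from compound 1 to compound 3 (0.19 log units; within the scatter) does not. Compound 3 therefore has the lowest number of the three, though it is not separated from compound 1 beyond the scatter, so the two can only be called similar.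

Compound 4 `CN(c1ccc2[nH]c(-c3n[nH]c4ccccc34)cc2n1)S(=O)(=O)c1ccc(OC(F)(F)F)cc1` is compound 3 with one change: trifluoromethoxy in place of chloro on an aromatic carbon. Going by the values given here, none of the measured steps touches the same spot; they swap the whole group on the nitrogen or exchange the ring on the carbonyl carbon, so no step bears directly on this change. Among the compounds with values here, nothing among the measured compounds shows that altering a group on this aromatic ring moves the number far. The expectation is therefore a step of about a 1.0-fold higher number from compound 3 to compound 4 (0.00 log units; within the scatter) in this assay, which is within the scatter. Compound 4 is estimated to give 6000 nM in this assay, with a likely range from 2000 nM to 18000 nM.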

Compound 4, half-maximal inhibitory concentration: 6040 nM
Compound 4: middle estimate off by 1.0-fold (0.00 log units), on the low side; the range from low to high includes it.
By their numbers in this assay, from the lowest: compounds 3, 4 and 1 (each within the scatter of the next); then compound 2.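

In this assay, going by these compounds alone, the step of a 1.0-fold higher number from compound 3 to compound 4 (0.00 log units; within the scatter) is the first measured change at this spot, on an aromatic carbon of the six-membered ring and para to a large group; the earlier steps instead replaced the whole group on the nitrogen or the ring on the carbonyl carbon. Here, chloro with its 1 heavy atom gives way to trifluoromethoxy with 5 heavy atoms and 1 hydrogen-bond acceptor, yet compound 3 and compound 4 read alike, so this one exchange at this carbon is tolerated in the sulfonyl compounds, though a single pair sets no general rule. Nothing measured here accounts for this match between the two compounds.

The compounds shown leave open whether a group of a different kind at this carbon, such as an amine or a carboxylic acid, would also read like compound 3, or whether plain hydrogen there would. They also leave open whether trifluoromethoxy in place of the fluoro of compound 1 would give a similar result when the ring is attached through a carbonyl rather than a sulfonyl group.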